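Adding an aminobenzylamino group to a potent serotonin-receptor binder

The compounds below may be only part of what the source reports. "The series", "measured", "known", "first", "only" and "open" are said of these compounds alone.

Measured compounds:
Compound 1 `CNc1nc(N2CC(N(C)C)C2)nc2ccc(Cl)cc12`: 468 nM
Compound 2 `CNc1nc(NCCC2CCN(C)C2)nc2ccc(Cl)cc12`: 11700 nM
Compound 3 `CN1CCN(c2ncc3cc(Cl)ccc3n2)CC1`: 7.41 nM

In an assay on HEK293 cells for displacement of a labelled ligand from 5-hydroxytryptamine receptor 3A (Homo sapiens), read by scintillation counting, with a stated time of 24 h, in the presence of a further agent that is not named here (on this read-out higher numbers stand for weaker inhibition and lower numbers for stronger inhibition), compound 3 gives the lowest number of the three, well beyond the scatter from compound 1 and compound 2, so it is the strongest binder shown. Compound 4 `CN1CCN(c2nc(NCc3ccc(N)cc3)c3cc(Cl)ccc3n2)CC1` differs from compound 3 by one change: (4-aminobenzyl)amino in place of hydrogen on an aromatic carbon, on the aromatic carbon next to the ring nitrogen and meta to the 4-methylpiperazin-1-yl group. Among the measured compounds shown here, no measured pair shows this exact step. A sizeable group added to a compact, tight binder more often loosens than tightens binding, so a step toward weaker binding, of moderate size, is expected: a 13-fold higher number from compound 3 to compound 4 (1.13 log units; beyond the scatter). Compound 4 is therefore estimated at 100 nM, with a likely range from 15 nM to 600 nM.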

Compound 4, inhibition constant: 2.69 nM
Estimate against measurement, compound 4: 37-fold (1.57 log units) above; measured number outside the range, below it.
By their numbers in this assay, from the lowest: compound 4; then compound 3; then compound 1; then compound 2.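

In this assay the aromatic carbon next to the ring nitrogen accepts a group of 9 heavy atoms with no loss of binding. Putting (4-aminobenzyl)amino in place of hydrogen gives a 2.8-fold lower number from compound 3 to compound 4 (0.44 log units; beyond the scatter) and so a modest gain, beyond the scatter. Among the compounds shown here, the earlier compounds offered no single-change comparison, so this is the first direct reading of a change at this position. As far as these compounds go, whether a plain benzylamino group, without the amine, or a longer chain would do the same at this carbon stays open. Nothing given here explains the direction of this step.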